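A Difluorocyclobutyl Swap on Compound 1

The source may hold more compounds than are shown below. What is called first, only, known or untested is meant among the compounds shown, and "the series" means these compounds.

Within the data shown here, in an ADME assay on microsomes from liver (Mus musculus) for metabolic stability, read by LC-MS, using NADPH, with a stated time of 60 min, tested at 0.1 uM (a lower number here means that less of the compound is left, a higher number that more of the compound is left), compound 1 `Fc1ccc(Nc2cc3[nH]c(Nc4ccc(N5CCN(CC6CC6)CC5)cn4)nc3cn2)cc1C(F)(F)F` gives 41%, the higher of the two numbers measured so far, while compound 2 `C[C@@H]1CN(c2ccc(Nc3nc4cnc(Nc5ccc(F)c(C(F)(F)F)c5)cc4[nH]3)nc2)C[C@H](C)O1` gives 6%. The step between them, a number 35 percentage points lower from compound 1 to compound 2 (beyond the scatter), is large and comes with 2,6-dimethylmorpholin-4-yl in place of 4-(cyclopropylmethyl)piperazin-1-yl.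

Compound 3 `FC1(F)CC(Nc2cc3[nH]c(Nc4ccc(N5CCN(CC6CC6)CC5)cn4)nc3cn2)C1` keeps the 4-(cyclopropylmethyl)piperazin-1-yl of compound 1 and changes a different part of the molecule. It carries 3,3-difluorocyclobutyl in place of 4-fluoro-3-(trifluoromethyl)phenyl on a nitrogen on an aromatic ring. Among the measured compounds shown here, no measured step covers this exchange, so the data give no firm direction for it. For the measured compounds named here, the one measured step bears on it only indirectly: a number 35 percentage points lower from compound 1 to compound 2 (beyond the scatter) shows that a single exchange elsewhere on the shared core can move this assay by a wide margin, which argues for a broad range.

With no step beyond the scatter firmly expected, the estimated change is a number 4 percentage points higher from compound 1 to compound 3 (within the scatter). For compound 3 the expected value is 45%, with an estimated range from 15% to 78%.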

Compound 3, percent of the compound remaining: 54%
Estimate against measurement, compound 3: 9 percentage points below; the measured number falls inside the stated range.
By their numbers in this assay, from the lowest: compound 2; then compound 1; then compound 3.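

In this assay, the position on a nitrogen on an aromatic ring also proves able to move the read-out: a number 13 percentage points higher from compound 1 to compound 3 (beyond the scatter), with 3,3-difluorocyclobutyl in place of 4-fluoro-3-(trifluoromethyl)phenyl. The earlier exchange, of the 4-(cyclopropylmethyl)piperazin-1-yl, lowered the number, whereas this one raises it, and it shows that the six-membered aromatic ring of carbon only can give way to a smaller four-membered non-aromatic ring without a loss in this read-out. Nothing available explains the rise, and the step itself is all that can be reported.

The compounds shown do not separate the part played by the two fluorines from that of the ring, and a plain cyclobutyl or a cyclohexyl on the same nitrogen would bear directly on that question. From the compounds shown here alone, it also remains open whether 3,3-difluorocyclobutyl would raise the number in the same way alongside 2,6-dimethylmorpholin-4-yl, or whether the step holds only with the 4-(cyclopropylmethyl)piperazin-1-yl in place.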